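Benzothiazole amide series: methoxy for fluoro on the fused ring

This account rests on a few compounds, and the source may have more. Where it says the series, first, only, none or still open, it means among the compounds named here.

Going by the values given here, in a functional assay on HeLa cells (Homo sapiens) for cytotoxicity, read by MTT assay, with a stated time of 48 h (on this read-out higher numbers stand for weaker inhibition and lower numbers for stronger inhibition), compound 2 `O=C(Nc1nc2ccc(F)cc2s1)c1cc(-c2ccc(F)cc2)n2nc(-c3ccccc3)cc2n1` gives 29500 nM, the highest of the three numbers measured so far. Compound 3 `COc1cc(-c2cc(C(=O)Nc3nc4ccc(F)cc4s3)nc3cc(-c4ccccc4)nn23)cc(OC)c1OC` gives 25100 nM in this assay, and the two lie within the scatter; compound 1 `O=C(Nc1nc2ccc(Cl)cc2s1)c1cc(-c2ccc(F)cc2)n2nc(-c3ccccc3)cc2n1` gives 9770 nM, and the step of a 3.0-fold higher number from compound 1 to compound 2 (0.48 log units; beyond the scatter) is the only one beyond the scatter. The step of a 1.2-fold lower number from compound 2 to compound 3 (0.07 log units; within the scatter) changes a group elsewhere on the shared core and stays within the scatter.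

Compound 4 `COc1ccc2nc(NC(=O)c3cc(-c4ccc(F)cc4)n4nc(-c5ccccc5)cc4n3)sc2c1` is compound 2 with methoxy in place of fluoro on an aromatic carbon. Among the compounds with values here, only the step from compound 1 to compound 2 alters the group on this same aromatic carbon of the fused ring system, and it was modest. Within the data shown here, no measured compound carries a methoxy there, so the direction is open; a step of about the size of that between compound 1 and compound 2 is the most the data support, and a number within the scatter of compound 2 is equally plausible.

Compound 4 is therefore expected to give about 15000 nM in this assay, with a plausible range of 4000 nM to 50000 nM. The expected step of a 2.0-fold lower number from compound 2 to compound 4 (0.29 log units; within the scatter) leans toward a lower number, since chloro in compound 1 gave 9770 nM.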

Compound 4, half-maximal inhibitory concentration: 17300 nM
Compound 4: middle estimate off by 1.2-fold (0.06 log units), on the low side; the measured number falls inside the stated range.
By their numbers in this assay, from the lowest: compounds 1, 4, 3 and 2 (each within the scatter of the next, the first and the last beyond it).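

In this assay methoxy on this aromatic carbon gives a 1.7-fold lower number from compound 2 to compound 4 (0.23 log units; within the scatter) and, set against chloro, a 1.8-fold higher number from compound 1 to compound 4 (0.25 log units; within the scatter) as its second step. Compound 4 therefore cannot be told apart from either compound 1 or compound 2, even though a 3.0-fold higher number from compound 1 to compound 2 (0.48 log units; beyond the scatter) separates those two. Methoxy, with two heavy atoms in place of one and a hydrogen-bond acceptor, thus stays within the scatter of both halogen compounds, and the chloro and fluoro pair remains the only step at this position beyond the scatter.

Open, going by these compounds, are an amine, a carboxylic acid or a longer chain such as ethoxy here, and whether the methoxy step holds with 3,4,5-trimethoxyphenyl in place of 4-fluorophenyl on the shared core. Nothing available explains the steps at this position.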